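The compounds below may be only part of what the source reports. "The series", "measured", "known", "first", "only" and "open" are said of these compounds alone.

Measured so far in a functional assay on G-361 cells (Homo sapiens) for cytotoxicity, read by sulforhodamine B assay; a lower number here means a stronger inhibitor of growth, a higher number a weaker inhibitor of growth:
compound 1 `CCCCNc1nc(C)nc2c1cnn2-c1ccccc1`, > 100000 nM;
compound 2 `Cc1nc(Nc2ccccc2)c2cnn(-c3ccccc3)c2n1`, > 100000 nM.

Compound 1 reaches only a limit in this assay, namely > 100000 nM, the upper edge of what this assay can read. Compound 2 likewise gives only a limit, > 100000 nM. The step that the two limits leave unreadable from compound 1 to compound 2 therefore has no readable size, as the limit of > 100000 nM in this assay, at which 2 of the 2 values shown sit, records. Compound 3 `CCNc1nc(C)nc2c1cnn2-c1ccccc1` differs from compound 2 by ethyl in place of phenyl on a nitrogen on an aromatic ring. For the measured compounds named here, the single measured step that touches this position, a step that the two limits leave unreadable from compound 1 to compound 2, runs the other way between two limits and so offers neither direction nor size. Both measured neighbours of compound 3 sit at the limit, and the data hold nothing that points away from it. Compound 3 is therefore expected to remain at that limit, with an expected step of a number no higher from compound 2 to compound 3 (the limit leaves the size open). The estimate for compound 3 is 100000 nM, between 50000 nM and 200000 nM.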

Compound 3, concentration for total growth inhibition: > 100000 nM
Compound 3: no number, only a limit; the forecaster's own chance of this, stated with the estimate: 85%; the middle value lies on the limit itself.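

For the compounds shown here, compound 3 also gives only a limit in this assay, so no step among compound 1, compound 2 and compound 3 can be read: the limit of > 100000 nM in this assay, at which 3 of the 3 values shown sit. The compounds shown leave open how strongly each inhibits growth, and whether changing the group on the nitrogen alters that at all.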